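Compound 4: a ring swap near the limit

The source may report more compounds than this note shows. Statements on the series, on what has been measured and on what is new or still open speak of the compounds shown alone.

For the measured compounds named here, in a functional assay on A549 cells (Homo sapiens) for cytotoxicity, read by MTT assay, with a stated time of 68 h (on this read-out higher numbers stand for weaker inhibition and lower numbers for stronger inhibition), compound 3 (`O=C(Nc1cccc(-c2cccs2)c1)C(Cl)Cl`) gives 47600 nM, the only true number among the three compounds measured so far. Compound 1 (`O=C(Nc1cccc(-c2ccsc2)c1)C(Cl)Cl`) reads > 50000 nM, which is a limit and not a number. Compound 2 (`O=C(Nc1cccc(-c2ccccn2)c1)C(Cl)Cl`) reads > 50000 nM, again a limit.

Compound 4 (`O=C(Nc1cccc(-c2nccs2)c1)C(Cl)Cl`) has not been measured. It carries 1,3-thiazol-2-yl in place of the thiophen-2-yl of compound 3, on an aromatic carbon of a six-membered aromatic ring of carbon only, meta to a group of 6 heavy atoms: 1,3-thiazol-2-yl in place of thiophen-2-yl on an aromatic carbon.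

The closest guides are earlier swaps of this same ring. They show an at least 1.0-fold lower number from compound 1 to compound 3 (0.02 log units; that floor lies within the scatter) and an at least 1.0-fold lower number from compound 2 to compound 3 (0.02 log units; that floor lies within the scatter), and also a step that the two limits leave unreadable from compound 1 to compound 2. Going by the values given here, the series so far is defined by the limit of > 50000 nM in this assay, at which 2 of the 3 values shown sit, so none of these swaps shows a real shift. No step beyond the scatter is therefore expected, and the estimated change is a 1.1-fold higher number from compound 3 to compound 4 (0.02 log units; within the scatter). The expected value for compound 4 is 50000 nM, with an estimated range of 25000 nM to 100000 nM.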

Compound 4, half-maximal inhibitory concentration: > 50000 nM
Compound 4 gave a limit, no number; the forecaster's own chance of this, stated with the estimate: 60%; the middle value lies on the limit itself.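

For the compounds shown here, putting 1,3-thiazol-2-yl in place of thiophen-2-yl brings a ring nitrogen to this position, yet in this assay the one readable step is an at least 1.0-fold higher number from compound 3 to compound 4 (0.02 log units; that floor lies within the scatter), so this change produces no shift that stands out from the scatter. The steps to compound 4 from compound 1 and from compound 2 have limits at both ends and cannot be read. A five-membered aromatic ring with 2 hetero atoms now joins the other rings tried at this place, and the series stays pinned at the same ceiling: the limit of > 50000 nM in this assay, at which 3 of the 4 values shown sit.

Every compound shown keeps an aromatic ring at this place, so whether an amine, a carboxylic acid or a longer chain here would give a true number well clear of the limit stays open. Also open, on these data alone, is what a change elsewhere on the shared core would do to this read-out.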